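This account rests on a few compounds, and the source may have more. Where it says the series, first, only, none or still open, it means among the compounds named here.

Measured compounds:
compound 1, `CCC(CC)/N=c1\c(O)c(O)\c1=N/Cc1ccc(C#N)cc1`: 1300 nM
compound 2, `CCc1cc(C#N)ccc1C/N=c1\c(O)c(O)\c1=N/C(C)(C)C`: 240 nM
compound 3, `CN(C)c1c(NCc2ccc(C#N)cc2)c(=O)c1=O`: > 30000 nM

In a functional assay for inhibition, with Rattus norvegicus as the target (a higher number here means a weaker inhibitor, a lower number a stronger inhibitor), compound 1 gives 1300 nM, the highest of the two numbers recorded, with compound 2 sitting at 240 nM, a gap beyond the scatter. Compound 3 reaches only a limit of the assay in this assay, namely > 30000 nM; (the limit of > 30000 nM in this assay, at which 1 of the 3 values shown sits). Compound 4, `CCC(C)(C)/N=c1\c(O)c(O)\c1=N/Cc1ccc(C#N)cc1`, has not yet been measured. It differs from compound 1 in one place: 1,1-dimethylpropyl in place of pentan-3-yl on a double-bonded nitrogen. Within the data shown here, no measured pair isolates this change, so the expectation for compound 4 rests on compound 2 alone, which carries a branched group on that nitrogen and gives 240 nM, though compound 2 also differs from compound 1 elsewhere. Compound 4 is therefore expected to give a lower number than compound 1, a step of a 2.6-fold lower number from compound 1 to compound 4 (0.41 log units; beyond the scatter), likely beyond the scatter. The estimate for compound 4 in this assay is 500 nM, between 150 nM and 2000 nM.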

Compound 4, half-maximal inhibitory concentration: 1100 nM
For compound 4 the middle estimate is 2.2-fold (0.34 log units) below the measured one; the measured number falls inside the stated range.
By their numbers in this assay, from the lowest: compound 2; then compounds 4 and 1 (each within the scatter of the next). At a limit, above all of these: compound 3.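

Replacing pentan-3-yl with 1,1-dimethylpropyl on a double-bonded nitrogen gives, in this assay, a 1.2-fold lower number from compound 1 to compound 4 (0.07 log units; within the scatter). Among these compounds, this is the first comparison here that isolates the group at this position, and it shows that these two five-carbon groups, joined differently, cannot be told apart in this read-out. Compound 2 differs from both compounds in more than one place, so this pair alone speaks to the change, and nothing measured here offers a reason for the result.

On these data alone, it remains open whether the number would also hold with a longer straight chain, a cyclohexyl group or a chain ending in an amine on this nitrogen. Which of the differences in compound 2 accounts for its printed value also remains unresolved, as no single-place pair separates them.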